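Dichlorophenyl in Place of Phenyl Among Three Growth Inhibitors

This account rests on a few compounds, and the source may have more. Where it says the series, first, only, none or still open, it means among the compounds named here.

Compound 1, `CC/C(=C(\c1ccccc1)c1ccc(NC(=O)C(C)C)cc1)c1ccccc1`, gives in a functional assay on MCF7 cells (Homo sapiens) for inhibition, read by trypan blue exclusion, with a stated time of 72 h; a lower number here means a stronger inhibitor of growth, a higher number a weaker inhibitor of growth > 30000 nM, which is a limit of the assay and not a number.
Compound 2, `CC/C(=C(\c1ccccc1)c1ccc(NC(=O)C(C)C)cc1)c1ccc(Cl)cc1Cl`, gives in this assay 8300 nM.
Compound 3, `CC/C(=C(/c1ccc(O)cc1)c1ccc(NC(=O)C(C)C)cc1)c1ccccc1`, gives in this assay 16400 nM.

Within the data shown here, the one measured step is the change (2,4-dichlorophenyl in place of phenyl on a double-bonded chain carbon bound to a double-bonded chain carbon and a saturated chain carbon), which gives an at least 3.6-fold lower number from compound 1 to compound 2 (0.55 log units; beyond the scatter). That step rests on (the limit of > 30000 nM in this assay, at which 1 of the 3 values shown sits), so its size is known only as a lower bound. Compound 3 and compound 2 have values within the scatter of each other, and the difference between the core of compound 3 and the core of compound 1 is not broken down here.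

Compound 4, `CC/C(=C(/c1ccc(O)cc1)c1ccc(NC(=O)C(C)C)cc1)c1ccc(Cl)cc1Cl`, is not yet measured. It differs from compound 3 by 2,4-dichlorophenyl in place of phenyl on a double-bonded chain carbon bound to a double-bonded chain carbon and a saturated chain carbon, and the place of the change is the same word for word as in the step from compound 1 to compound 2, so this is the same change. On the strength of an at least 3.6-fold lower number from compound 1 to compound 2 (0.55 log units; beyond the scatter) for compound 2, the expected step is a 3.3-fold lower number from compound 3 to compound 4 (0.52 log units; beyond the scatter), kept moderate since the earlier step is a lower bound only and is seen once. In this assay compound 4 is therefore estimated at 5000 nM, expected to fall between 1500 nM and 15000 nM.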

Compound 4, concentration for 50% growth inhibition: 26600 nM
For compound 4 the middle estimate is 5.3-fold (0.73 log units) below the measured one; the measured number lies above the stated range.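

In this assay, the same exchange of phenyl for 2,4-dichlorophenyl now gives a 1.6-fold higher number from compound 3 to compound 4 (0.21 log units; within the scatter), so the gain seen on the core of compound 1 does not carry over to the core of compound 3, and the two readings of this one change stand clearly apart: the same change on two cores in this assay, an at least 3.6-fold lower number (0.55 log units; beyond the scatter) from compound 1 to compound 2 and a 1.6-fold higher number (0.21 log units; within the scatter) from compound 3 to compound 4, at least 5.8-fold (0.76 log units) apart, beyond the scatter of two such steps
The earlier of these two steps rests on a value that is a limit of the assay and not a number, so its true size remains unknown: the limit of > 30000 nM in this assay, at which 1 of the 4 values shown sits.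
The comparison shows that, in this series, the effect of the change depends on the core that carries it, but with one pair on each of two cores it gives no rule for any further core and does not show what in the cores separates the two results.

On these data alone, it remains open whether a phenyl carrying fluorine or a methoxy group in place of the chlorines would follow compound 2 or compound 4 on these two cores. As far as these compounds go, it is also open whether the same split between the cores would remain with an amine or a longer chain in place of the amide group that all four compounds share.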